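This account rests on a few compounds, and the source may have more. Where it says the series, first, only, none or still open, it means among the compounds named here.

Three of the four compounds in this set have been measured in a functional assay on A549 cells (Homo sapiens) for antiproliferative activity, read by MTT assay, with a stated time of 72 h; a higher number here means a weaker inhibitor, a lower number a stronger inhibitor. Compound 1 `COc1cccc(N2C(=O)COc3ccc(-c4cnc(Cl)c(NS(=O)(=O)c5ccc(F)cc5)c4)cc32)c1` gives 32700 nM in this assay. Compound 2 `O=C1COc2ccc(-c3cccc(NS(=O)(=O)c4ccc(F)cc4)c3)cc2N1` gives 32100 nM in this assay, a number that lies within the usual scatter of that of compound 1. For compound 3 `O=C1COc2ccc(-c3cnc(Cl)c(NS(=O)(=O)c4ccc(F)cc4)c3)cc2N1` the result in this assay is only a limit, > 40000 nM, not a number; this is the limit of > 40000 nM in this assay, at which 1 of the 3 values shown sits. The difference between the core of compound 2 and the core of compound 3 is not broken down here.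

One structural change occurs twice among these compounds. From compound 3 to compound 1 it is 3-methoxyphenyl in place of hydrogen on an amide-type nitrogen in a ring and the measured step is an at least 1.2-fold lower number from compound 3 to compound 1 (0.08 log units; that floor lies within the scatter), a floor that lies within the scatter, so the change is not seen to move the number in a way that can be told apart from noise.

Compound 4 `COc1cccc(N2C(=O)COc3ccc(-c4cccc(NS(=O)(=O)c5ccc(F)cc5)c4)cc32)c1` has not yet been measured. It stands to compound 2 as compound 1 stands to compound 3, the change being (3-methoxyphenyl in place of hydrogen on an amide-type nitrogen in a ring); the place of the change reads identically in both cases, so this is the same change. Resting on an at least 1.2-fold lower number from compound 3 to compound 1 (0.08 log units; that floor lies within the scatter), the step to compound 4 is expected to be a 1.2-fold lower number from compound 2 to compound 4 (0.09 log units; within the scatter). Compound 4 is therefore estimated at 26000 nM in this assay, with a likely range from 12000 nM to 40000 nM.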

Compound 4, half-maximal inhibitory concentration: > 40000 nM
Compound 4 ended at the assay's limit (the forecaster's own chance of this, stated with the estimate: 30%); at least 1.5-fold (0.18 log units) between middle value and limit.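

In this assay compound 4 gives > 40000 nM, which is a limit of the assay and not a number. On this core, placing 3-methoxyphenyl on the amide-type nitrogen in a ring gives an at least 1.2-fold higher number from compound 2 to compound 4 (0.09 log units; that floor lies within the scatter), so the change is not seen to move the number in a way that can be told apart from noise. Set beside the earlier step, this shows neither that the change carries over from one core to the other in the same way nor that it behaves differently, since each step rests on a limit: the same change on two cores in this assay, an at least 1.2-fold lower number (0.08 log units; that floor lies within the scatter) from compound 3 to compound 1 and an at least 1.2-fold higher number (0.09 log units; that floor lies within the scatter) from compound 2 to compound 4; the limit leaves it open whether they differ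

The compounds shown leave open how large any effect of this change really is on either core, since some of the readings stop at the same ceiling: the limit of > 40000 nM in this assay, at which 2 of the 4 values shown sit. They also leave open whether another group on the amide-type nitrogen in a ring, such as a short alkyl chain ending in an amine or in a carboxylic acid, would give measured numbers on both cores, which would allow the two steps to be compared directly.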